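Cytotoxicity in HEL cells: chloro to fluoro step

This account rests on a few compounds, and the source may have more. Where it says the series, first, only, none or still open, it means among the compounds named here.

Measured compounds:
compound 1, `COc1cc(/C=N/NC(=O)COc2cccc3ccccc23)cc(OC)c1OC`: >= 20 ug/mL
compound 2, `O=C(COc1cccc2ccccc12)N/N=C/c1ccc(Cl)cc1`: 100 ug/mL
compound 3, `C/C(=N\NC(=O)COc1cccc2ccccc12)c1ccc(O)cc1`: 20 ug/mL

In an ADME assay on HEL cells (Homo sapiens) for cytotoxicity (a lower number here means that less compound is tolerated, a higher number that more compound is tolerated), compound 2 gives 100 ug/mL, the higher of the two numbers recorded. Compound 3 gives 20 ug/mL, a lower number, and the gap between these two lies beyond the scatter. For compound 1 the value >= 20 ug/mL is a limit of the assay and not a number; (the limit of >= 20 ug/mL in this assay, at which 1 of the 3 values shown sits). Compound 4, `O=C(COc1cccc2ccccc12)N/N=C/c1ccc(F)cc1`, is not yet measured in this assay. Relative to compound 2 it shows (fluoro in place of chloro on an aromatic carbon). Among the compounds with values here, no step between measured compounds matches this change, so no measured size is available for it. The step is expected to be small, within the scatter, in either direction. Compound 4 is expected to give 100 ug/mL in this assay, in the range 30 ug/mL to 200 ug/mL, an estimated step of no change at the digits printed from compound 2 to compound 4 (within the scatter).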

Compound 4, minimum cytotoxic concentration: 100 ug/mL
Estimate against measurement, compound 4: no gap at the digits printed; the range from low to high includes it.
By their numbers in this assay, from the lowest: compound 3; then compounds 2 and 4 (each within the scatter of the next).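

In this assay, the change from 4-chlorophenyl to 4-fluorophenyl, on an aromatic carbon para to a large group, gives no change at the digits printed from compound 2 to compound 4 (within the scatter). Within the data shown here, this is the only step at this position that can be read, as the earlier compounds differ from one another in more than one place. No measurement shown here bears on a cause for this result.

Going by these compounds, a bromo group, an amine or a carboxylic acid at this position remains open. So does whether the same exchange gives a similar step on any other core.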